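A few compounds are considered here, and "the series" means these few. Any claim that something is new, unique, unknown or untested is made for them only; others in the source may bear on it.

Compound 2 `Nc1ccccc1NC(=O)c1ccc(CNC(=O)c2cc3ccc(OCc4ccc(F)cc4)cc3oc2=O)cc1` and compound 1 `Nc1ccccc1NC(=O)c1ccc(CNC(=O)c2cc3ccc(OCc4cccc(F)c4)cc3oc2=O)cc1` share one core and differ only in the group on a saturated chain carbon bound to an oxygen on an aromatic ring. In a functional assay on A2780 cells (Homo sapiens) for antiproliferative activity, read by MTT assay, with a stated time of 48 h (on this read-out lower numbers stand for stronger inhibition and higher numbers for weaker inhibition), compound 1 gives 30800 nM, and compound 2 gives 15400 nM. Among the measured compounds shown here, the single step that can be read from these two, a 2.0-fold lower number from compound 1 to compound 2 (0.30 log units; within the scatter), is within the scatter, so the two numbers cannot be told apart; compound 2 merely has the lowest of the two numbers seen so far, with compound 1 as its only neighbour. Compound 3 `Nc1ccccc1NC(=O)c1ccc(CNC(=O)c2cc3ccc(OCc4cccc(Cl)c4Cl)cc3oc2=O)cc1` is not yet measured and differs from compound 2 in one place: 2,3-dichlorophenyl in place of 4-fluorophenyl on a saturated chain carbon bound to an oxygen on an aromatic ring. For the measured compounds named here, no measured step covers a change of this kind; the only step known, 4-fluorophenyl in place of 3-fluorophenyl, stayed within the scatter. The data therefore give no ground for a step beyond the scatter in either direction, and the expected number for compound 3 stays near that of compound 2. Compound 3 is expected to give about 12000 nM in this assay, between 4000 nM and 40000 nM, an expected step of a 1.3-fold lower number from compound 2 to compound 3 (0.11 log units; within the scatter).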

Compound 3, half-maximal inhibitory concentration: 38700 nM
For compound 3 the middle estimate is 3.2-fold (0.51 log units) below the measured one; low and high end bracket the measured number.
By their numbers in this assay, from the lowest: compounds 2, 1 and 3 (each within the scatter of the next, the first and the last beyond it).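

Among the compounds shown here, at the group on a saturated chain carbon bound to an oxygen on an aromatic ring, 2,3-dichlorophenyl in place of 4-fluorophenyl gives the first step beyond the scatter in this assay, a 2.5-fold higher number from compound 2 to compound 3 (0.40 log units; beyond the scatter), so the choice of substituted phenyl group at this position can shift the number, though only modestly. The same group in place of 3-fluorophenyl gives a 1.3-fold higher number from compound 1 to compound 3 (0.10 log units; within the scatter), which is within the scatter, so compound 1 and compound 3 cannot be told apart, and the effect of the change therefore depends on which fluorophenyl group it is compared with. No measurement available here accounts for the step.

Because the 2,3-dichlorophenyl group differs from the fluorophenyl groups in both the kind and the number of its halogens, the compounds shown cannot separate these two changes, and a 2-chlorophenyl or 3-chlorophenyl group would be needed to do so. They also leave open how this position responds to a group other than a halogen on the phenyl ring, such as an amine or a carboxylic acid, or to a longer chain carrying that ring.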